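Side chain extended at the limit of the assay

The source may hold more compounds than are shown below. What is called first, only, known or untested is meant among the compounds shown, and "the series" means these compounds.

In a functional assay on HeLa cells (Homo sapiens) for cytotoxicity, read by MTT assay (a higher number here means a weaker inhibitor, a lower number a stronger inhibitor), compound 1 (`Cc1c(O)cc(CCCC(C)C)oc1=O`) gives > 200000 nM as a limit of the assay, not a number. Compound 2 (`Cc1c(O)cc(CCCCC(C)(C)O)oc1=O`) gives > 200000 nM, again only a limit. Among the compounds with values here, the one measured step (a step that the two limits leave unreadable from compound 1 to compound 2) therefore has no readable size, and the evidence so far amounts to the limit of > 200000 nM in this assay, at which 2 of the 2 values shown sit, alone.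

Compound 3 (`Cc1c(O)cc(CCCCC(C)[C@H](C)O)oc1=O`) carries 2-hydroxy-1-methylpropyl in place of 1-hydroxy-1-methylethyl on a saturated chain carbon, four bonds along the chain from an aromatic carbon. No measured size can be carried over to this change, so the expectation rests on compound 2 and its limit of > 200000 nM in this assay alone. Only a small step (a number no higher from compound 2 to compound 3 (the limit leaves the size open)) with no clear direction is expected. For compound 3 the estimated value is 200000 nM with an expected range from 80000 nM to 400000 nM and a likely report as a limit again.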

Compound 3, half-maximal inhibitory concentration: > 200000 nM
Compound 3 was reported as a limit; the forecaster's own chance of this, stated with the estimate: 80%; the middle value sits exactly at the limit.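

Within the data shown here, compound 1, compound 2 and compound 3 all stand only as limits in this assay, so no step among them can be read. The compounds shown leave open whether any change to this side chain would give a readable value in this assay.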